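This account rests on a few compounds, and the source may have more. Where it says the series, first, only, none or still open, it means among the compounds named here.

Measured compounds:
- compound 1, `CC(C)N(C)c1ccc2cc(NC(=O)CCc3ccc(C(F)(F)F)cc3)ccc2n1`, 2 nM
- compound 2, `CC1CCCN1c1ccc2cc(NC(=O)CCc3ccc(C(F)(F)F)cc3)ccc2n1`, 5 nM
- compound 3, `O=C(CCc1ccc(C(F)(F)F)cc1)Nc1ccc2nc(N3CCC(c4ccccc4)C3)ccc2c1`, 25 nM

All three share one core and one amide side chain and differ only in the amine on the aromatic carbon. In an assay on isolated protein for displacement of a labelled ligand from melanin-concentrating hormone receptor 1 (Homo sapiens) (on this read-out lower numbers stand for stronger inhibition and higher numbers for weaker inhibition), compound 3 gives the highest number of the three: compound 2 sits nearer, compound 1 furthest, and both gaps lie beyond the scatter. The steps of a 2.5-fold higher number from compound 1 to compound 2 (0.40 log units; beyond the scatter), a 5.0-fold higher number from compound 2 to compound 3 (0.70 log units; beyond the scatter) and a 13-fold higher number from compound 1 to compound 3 (1.10 log units; beyond the scatter) all run the same way, the number rising as the amine grows from the acyclic group through the methylpyrrolidine to the phenylpyrrolidine.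

Compound 4, `O=C(CCc1ccc(C(F)(F)F)cc1)Nc1ccc2nc(N3CC4CC3CO4)ccc2c1`, makes the change (a group of 7 heavy atoms (5 carbon, 1 nitrogen, 1 oxygen; 2 five-membered non-aromatic rings with 1 hetero atom each) in place of a group of 11 heavy atoms (10 carbon, 1 nitrogen; one five-membered non-aromatic ring with 1 hetero atom, one six-membered aromatic ring of carbon only), on an aromatic carbon). Within the data shown here, the incoming group is smaller than the phenylpyrrolidine that leaves and is nearer in size to the amines of compounds 1 and 2, so a step in the opposite direction to a 5.0-fold higher number from compound 2 to compound 3 (0.70 log units; beyond the scatter) is expected; the bridged oxygen-containing ring has no measured counterpart here, so the estimate is held wide. Compound 4 is expected to give 8 nM in this assay, range 3 nM to 25 nM, an estimated step of a 3.1-fold lower number from compound 3 to compound 4 (0.49 log units; beyond the scatter).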

Compound 4, half-maximal inhibitory concentration: 13 nM
Estimate against measurement, compound 4: 1.6-fold (0.21 log units) below; measured number inside the range.
By their numbers in this assay, from the lowest: compound 1; then compound 2; then compounds 4 and 3 (each within the scatter of the next).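

At this position, a much smaller bridged oxygen-containing amine cannot be separated from the 3-phenylpyrrolidin-1-yl group in this assay, with a 1.9-fold lower number from compound 3 to compound 4 (0.28 log units; within the scatter) as the step. Removing the phenyl-bearing group therefore does not by itself restore the lower numbers: a 2.6-fold higher number from compound 2 to compound 4 (0.41 log units; beyond the scatter) and a 6.5-fold higher number from compound 1 to compound 4 (0.81 log units; beyond the scatter) both remain beyond the scatter, even though the heavy-atom count of the incoming group is close to those of the amines in compounds 1 and 2. No measurement here bears on why the bridged group sits at this level.

On these data alone, whether the gap to compounds 1 and 2 goes with the ring oxygen or with the bridge stays open. A morpholine and an all-carbon bridged amine, each set on the same aromatic carbon, would separate those two features.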